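Working notes: from compound 2 to compound 4

The compounds below may be only part of what the source reports. "The series", "measured", "known", "first", "only" and "open" are said of these compounds alone.

Measured compounds:
compound 1 `CCOC(=O)C1=C(Nc2ccccc2)S/C(=C\c2ccc([N+](=O)[O-])c(O)c2)C1=O`: 51.2%
compound 2 `CCOC(=O)C1=C(Nc2ccccc2)S/C(=C\c2ccc(Br)c(O)c2)C1=O`: 39.8%
compound 3 `CCOC(=O)C1=C(Nc2ccccc2)S/C(=C\c2ccccc2C(F)(F)F)C1=O`: 29%

In a functional assay on JAR cells (Homo sapiens) for inhibition, read by MTT assay, with a stated time of 72 h, tested at 10 uM (on this read-out lower numbers stand for less inhibition and higher numbers for more inhibition at the one concentration tested (going by the name of the read-out)), compound 2 gives 39.8%, the second highest of the three numbers. Compound 1 gives 51.2%, the highest; compound 3 gives 29%, the lowest, and the gap from compound 2 to compound 3 is beyond the scatter. For the measured compounds named here, the only measured single-point step is a number 11.4 percentage points lower from compound 1 to compound 2 (beyond the scatter).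

Compound 4 `CCOC(=O)C1=C(Nc2ccccc2)S/C(=C\c2cccnc2)C1=O` is not yet measured. Its change from compound 2 is pyridin-3-yl in place of 4-bromo-3-hydroxyphenyl on a double-bonded chain carbon bound to a double-bonded ring carbon. Going by the values given here, no measured step touches this change: the one step seen swaps a group on an aromatic carbon, whereas here the whole aryl group on the double-bonded chain carbon is exchanged. Compound 3, which also lacks the hydroxyl, gives 29%, which is the nearest reference. The expected step is therefore a number 6.8 percentage points lower from compound 2 to compound 4 (within the scatter), a modest lowering, with low confidence. Compound 4 is estimated at 33%, in the range 15% to 50%.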

Compound 4, a percentage reported as inhibition, at one concentration (the size of the read-out at that concentration, not a potency): 32.1%
Beside the measured number, compound 4's estimate is 0.9 percentage points above it; the measured number falls inside the stated range.
By their numbers in this assay, from the lowest: compounds 3, 4 and 2 (each within the scatter of the next, the first and the last beyond it); then compound 1.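

Replacing the whole aryl group at this place, on a double-bonded chain carbon bound to a double-bonded ring carbon, gives a number 7.7 percentage points lower from compound 2 to compound 4 (within the scatter) in this assay. Compound 4 is the first compound shown with a hetero atom in this aromatic ring, and the exchange removes the bromo and the hydroxyl together, yet this pair cannot be told apart on this read-out, so neither group is shown to be required here. Nothing available explains this outcome.

The compounds shown leave open whether a 4-bromophenyl or a 3-hydroxyphenyl group alone would read like compound 2, so the bromo and the hydroxyl cannot be separated. Also open, on these data alone, is how an amine or a carboxylic acid on this aromatic ring would read.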